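Changing the ether group of compound 3

This account rests on a few compounds, and the source may have more. Where it says the series, first, only, none or still open, it means among the compounds named here.

Compound 1 `CCc1cc2oc(=O)n(CCC(=O)O)c2cc1Cl`: 1.94
Compound 2 `O=C(O)CCn1c(=O)oc2cc(OCc3ccccc3)c(Cl)cc21`: 2.71
Compound 3 `C[C@@H](Oc1cc2oc(=O)n(CCC(=O)O)c2cc1Cl)c1cccnn1`: 0.83

In a physicochemical assay for lipophilicity, read by HPLC, at pH 7.4 (on this read-out lower numbers stand for lower lipophilicity and higher numbers for higher lipophilicity), compound 3 stands lowest of the three measured compounds, under compound 1 and further still under compound 2. The next molecule, compound 4 `O=C(O)CCn1c(=O)oc2cc(OCC3CC3)c(Cl)cc21`, has not yet been measured. It differs from compound 3 in one place: a group of 4 heavy atoms (4 carbon; one three-membered non-aromatic ring of carbon only) in place of a group of 8 heavy atoms (6 carbon, 2 nitrogen; one six-membered aromatic ring with 2 hetero atoms), on an oxygen on an aromatic ring. The group on that oxygen therefore becomes cyclopropylmethyl, which holds carbon only.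

Among the compounds with values here, two measured steps bear on this change. The closer one shows a number 1.88 log units lower from compound 2 to compound 3 (beyond the scatter), and there a group of carbon only left that oxygen. The new change runs the opposite way, so a rise is expected in this assay, back towards compound 2 at 2.71. The other step shows a number 0.77 log units higher from compound 1 to compound 2 (beyond the scatter), so the smaller ethyl of compound 1 sits lower than the benzyloxy of compound 2. Cyclopropylmethyl is also smaller than the group in compound 2, so the return is expected to stop short of that value. With so few compounds, this remains a rough guide.

The result is an expected large upward move, estimated as a number 1.52 log units higher from compound 3 to compound 4 (beyond the scatter). The expected value for compound 4 is 2.35, within an estimated range from 1.95 to 2.75.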

Compound 4, distribution coefficient: 2.09
Compound 4: middle estimate off by 0.26 log units, on the high side, and the stated range covers the measured number.
By their numbers in this assay, from the lowest: compound 3; then compounds 1 and 4 (each within the scatter of the next); then compound 2.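

In this assay, putting cyclopropylmethyl on this oxygen in place of the group with the six-membered aromatic ring with 2 hetero atoms gives a number 1.26 log units higher from compound 3 to compound 4 (beyond the scatter) and so shows that a much smaller group of carbon only also reads well above compound 3. Size of the carbon-only group still counts on this oxygen, since cyclopropyl in place of phenyl on the saturated chain carbon gives a number 0.62 log units lower from compound 2 to compound 4 (beyond the scatter) and leaves compound 4 short of compound 2. Set against the plain ethyl group, the new ether gives a number 0.15 log units higher from compound 1 to compound 4 (within the scatter) and so cannot be told apart from the ethyl group on this read-out, which the earlier steps could not show. No measurement here explains why any of these steps has the size it has.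

The group that leaves in this change also carries a defined stereocentre and a branching methyl, so the compounds shown do not separate the effect of the ring nitrogens from that of the branch. A 1-phenylethyl group or an unbranched pyridazinylmethyl group on the same oxygen would pull those two apart.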